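Chloro in place of methylsulfinyl on the shared core

A few compounds are considered here, and "the series" means these few. Any claim that something is new, unique, unknown or untested is made for them only; others in the source may bear on it.

Compound 2 `C[S+]([O-])c1c(F)c(N)c2c(=O)cc(-c3ccc(N)c(F)c3)oc2c1F` stands highest of the two plain numbers in a functional assay on MCF7 cells (Homo sapiens) for cytotoxicity, read by neutral red uptake, with a stated time of 3 days (on this read-out lower numbers stand for stronger inhibition and higher numbers for weaker inhibition), where compound 2 gives 2500 nM. Its nearest neighbour is compound 1 `Nc1ccc(-c2cc(=O)c3c(N)c(F)c(Br)c(F)c3o2)cc1F`, which in this assay gives 160 nM; the step between them is a 16-fold higher number from compound 1 to compound 2 (1.19 log units; beyond the scatter). Compound 3 `Nc1ccc(-c2cc(=O)c3c(N)c(F)c(O)c(F)c3o2)cc1F` carries a hydroxy at the same place. In this assay compound 3 reaches only a limit, > 10000 nM, which is the limit of > 10000 nM in this assay, at which 1 of the 3 values shown sits. The steps toward it, an at least 4.0-fold higher number from compound 2 to compound 3 (0.60 log units; beyond the scatter) and an at least 62-fold higher number from compound 1 to compound 3 (1.79 log units; beyond the scatter), are therefore known only as minimum sizes.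

Compound 4 `Nc1ccc(-c2cc(=O)c3c(N)c(F)c(Cl)c(F)c3o2)cc1F` differs from compound 2 by one chlorine atom in place of a group of 3 heavy atoms (1 carbon, 1 oxygen, 1 sulfur; no ring), on an aromatic carbon. The step that bears most on this change is a 16-fold higher number from compound 1 to compound 2 (1.19 log units; beyond the scatter), since compound 1 also carries a single halogen at that place and compound 4 returns to one; the hydroxy steps run toward weaker inhibition, but they concern an oxygen rather than a halogen. Accordingly the expectation for compound 4 is a large step toward a lower number, a 13-fold lower number from compound 2 to compound 4 (1.10 log units; beyond the scatter). Compound 4 is estimated at 200 nM in this assay, with a range from 80 nM to 600 nM.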

Compound 4, half-maximal inhibitory concentration: 210 nM
Beside the measured number, compound 4's estimate is 1.1-fold (0.02 log units) below it; the range from low to high includes it.
By their numbers in this assay, from the lowest: compounds 1 and 4 (each within the scatter of the next); then compound 2. At a limit, above all of these: compound 3.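

Exchanging bromo for chloro at this place gives a 1.3-fold higher number from compound 1 to compound 4 (0.12 log units; within the scatter), so in this assay the two halogens cannot be told apart here. The weaker number of the methylsulfinyl compound is therefore not a contrast with bromo alone, for a second halogen recovers the same large step, a 12-fold lower number from compound 2 to compound 4 (1.08 log units; beyond the scatter), and compounds 1 and 4 together stand apart from the methylsulfinyl and hydroxy compounds. Against hydroxy the chloro group gives an at least 47-fold lower number from compound 3 to compound 4 (1.67 log units; beyond the scatter), a step known only as a minimum size, with compound 3 at a limit of the assay and not at a number: the limit of > 10000 nM in this assay, at which 1 of the 4 values shown sits.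

The compounds shown leave open whether iodo at this place would stay with bromo and chloro, and whether a non-halogen group of one heavy atom, such as methyl, or a small group such as nitrile or methoxy, would stand with the halogens or with the methylsulfinyl compound. They also leave open how an amine or a carboxylic acid at this place would read, and so how far the tolerated groups extend beyond the halogens.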